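The source may report more compounds than this note shows. Statements on the series, on what has been measured and on what is new or still open speak of the compounds shown alone.

In a functional assay on KYSE-70 cells for antiproliferative activity against KYSE-70 cell line (Homo sapiens), read by MTT assay, with a stated time of 72 h (on this read-out lower numbers stand for stronger inhibition and higher numbers for weaker inhibition), compound 1 `COc1ccccc1NC(=O)c1cc(=O)[nH]c2cc(Br)ccc12` gives > 20000 nM, which is a limit and not a number. Compound 3 `COc1ccc(OC)c(NC(=O)c2cc(=O)[nH]c3cc(Br)ccc23)c1` gives > 20000 nM, also a limit, so it stands at the limit of > 20000 nM in this assay, at which 2 of the 3 values shown sit. Compound 2 `O=C(Nc1cccc(F)c1)c1cc(=O)[nH]c2cc(Br)ccc12` gives a real number, 8900 nM. Compound 4 `COc1cccc(NC(=O)c2cc(=O)[nH]c3cc(Br)ccc23)c1` differs from compound 3 by hydrogen in place of methoxy on an aromatic carbon. Among the measured compounds shown here, the one measured step involving this kind of change, a step that the two limits leave unreadable from compound 1 to compound 3, adds a methoxy and gives no size to go on. For the measured compounds named here, the only guide is compound 2 at 8900 nM, so a modest gain seems possible. Even so, compound 4 may stay at the limit. The expected change is an at least 1.5-fold lower number from compound 3 to compound 4 (0.18 log units; that floor lies within the scatter), towards stronger inhibition. For compound 4 the estimate is 13000 nM, with an expected range from 5000 nM to 30000 nM.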

Compound 4, half-maximal inhibitory concentration: > 20000 nM
Compound 4: a limit, no number; the forecaster's own chance of this, stated with the estimate: 40%; at least 1.5-fold (0.18 log units) between middle value and limit.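

Taking the methoxy off compound 3 leaves compound 4 still at the limit, so the steps among compounds 1, 3 and 4 cannot be read, and the series stays bunched at one end: the limit of > 20000 nM in this assay, at which 3 of the 4 values shown sit. Methoxy in place of fluoro on an aromatic carbon does give a readable size in this assay, namely an at least 2.2-fold higher number from compound 2 to compound 4 (0.35 log units; beyond the scatter), so this swap costs activity beyond the scatter. The compounds shown leave open whether an amine or a carboxylic acid on that aromatic carbon would bring a real number.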